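Swapping an acyl group for a sulfonyl on a serine-like amide

The source may hold more compounds than are shown below. What is called first, only, known or untested is meant among the compounds shown, and "the series" means these compounds.

Measured compounds so far:
- compound 1 `CCCCCCCCCCCCCCNC(=O)[C@@H](N)[C@@H](C)O`: 14600 nM
- compound 2 `CCCCCCCCCCCCCCNC(=O)[C@@H](NC(=O)/C=C/c1ccccc1)[C@@H](C)O`: 64900 nM

In a functional assay on A-431 cells (Homo sapiens) for cytotoxicity, read by MTT assay, with a stated time of 48 h (on this read-out higher numbers stand for weaker inhibition and lower numbers for stronger inhibition), compound 1 gives 14600 nM, and compound 2 gives 64900 nM. Among the compounds with values here, compound 2 thus stands at the highest number of the two measured compounds, which on this read-out means the weaker of the two; the only comparison available is the step of a 4.4-fold higher number from compound 1 to compound 2 (0.65 log units; beyond the scatter).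

Compound 3 `CCCCCCCCCCCCCCNC(=O)[C@@H](NS(=O)(=O)c1ccc(C)cc1)[C@@H](C)O` is the next compound to be measured. It differs from compound 2 in one place: (4-methylphenyl)sulfonyl in place of (2-phenylethenyl)carbonyl on an amine nitrogen. Within the data shown here, the one measured step that bears on this change is the one from compound 1 to compound 2, where covering the free amine nitrogen with a carbonyl-bearing group gave a 4.4-fold higher number from compound 1 to compound 2 (0.65 log units; beyond the scatter). Compound 3 again carries a group on that same nitrogen, so it is expected to sit closer to compound 2 than to compound 1; the change from one aromatic substituent to another is expected to give a 1.1-fold lower number from compound 2 to compound 3 (0.03 log units; within the scatter), that is, no step beyond the scatter. Compound 3 is therefore estimated at 60000 nM, with a range from 25000 nM to 150000 nM.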

Compound 3, half-maximal inhibitory concentration: 12000 nM
Beside the measured number, compound 3's estimate is 5.0-fold (0.70 log units) above it, and the stated range ends above it.
By their numbers in this assay, from the lowest: compounds 3 and 1 (each within the scatter of the next); then compound 2.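

The new result shows that putting a group on this nitrogen does not by itself raise the number: in this assay, (4-methylphenyl)sulfonyl in place of (2-phenylethenyl)carbonyl gives a 5.4-fold lower number from compound 2 to compound 3 (0.73 log units; beyond the scatter), although both groups have the same count of heavy atoms and each carries one six-membered aromatic ring of carbon only. Set against the free amine, the same group gives a 1.2-fold lower number from compound 1 to compound 3 (0.09 log units; within the scatter), so compound 3 cannot be told apart from compound 1 here, and the weaker result of compound 2 goes with its (2-phenylethenyl)carbonyl group rather than with every group placed on that nitrogen. Nothing measured here explains the difference between these two groups.

As far as these compounds go, what remains open is which part of each group matters: an acetyl or a benzoyl group on the same nitrogen would test the carbonyl side, and a methylsulfonyl group would test the sulfonyl side without its aromatic ring. Also open, from the compounds shown here alone, is whether the same order would hold with a shorter chain in place of the long chain on the amide.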